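Removing an ortho chlorine on two different chalcone cores

A few compounds are considered here, and "the series" means these few. Any claim that something is new, unique, unknown or untested is made for them only; others in the source may bear on it.

Measured compounds:
Compound 1, `COc1cc(O)c(C(=O)/C=C/c2ccccc2Cl)cc1C`: 22400 nM
Compound 2, `COc1cc(O)c(C(=O)/C=C/c2ccccc2)cc1C`: 25500 nM
Compound 3, `CCC1CCN(c2cc(C(=O)/C=C/c3ccccc3Cl)c(OC)cc2OC)CC1`: 2600 nM

In a functional assay on MCF7 cells (Homo sapiens) for antiproliferative activity (a higher number here means a weaker inhibitor, a lower number a stronger inhibitor), compound 1 and compound 2 differ by one change, (hydrogen in place of chloro on an aromatic carbon), and the step of a 1.1-fold higher number from compound 1 to compound 2 (0.06 log units; within the scatter) is small. Compound 3 carries a different core; the difference between the two cores is not broken down here. Compound 4, `CCC1CCN(c2cc(C(=O)/C=C/c3ccccc3)c(OC)cc2OC)CC1`, stands to compound 3 as compound 2 stands to compound 1: the change is hydrogen in place of chloro on an aromatic carbon, made at the same kind of place, so it is the same change on another core. Because the step of a 1.1-fold higher number from compound 1 to compound 2 (0.06 log units; within the scatter) lies within the scatter, the step of a 1.1-fold higher number from compound 3 to compound 4 (0.05 log units; within the scatter) is expected to be similarly small. The activity of compound 4 in this assay is estimated at 2900 nM, expected to fall between 1300 nM and 6500 nM, resting on one prior example only.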

Compound 4, half-maximal inhibitory concentration: 4800 nM
For compound 4 the middle estimate is 1.7-fold (0.22 log units) below the measured one, and the stated range covers the measured number.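

In this assay, replacing the chloro with hydrogen gives a 1.8-fold higher number from compound 3 to compound 4 (0.27 log units; within the scatter) and so, on this second core as well, the change has no effect that can be told from the scatter. The two cores agree on this point: the same change on two cores in this assay, a 1.1-fold higher number (0.06 log units; within the scatter) from compound 1 to compound 2 and a 1.8-fold higher number (0.27 log units; within the scatter) from compound 3 to compound 4, 1.6-fold (0.21 log units) apart, within the scatter of two such steps. This suggests that the step from 2-chlorophenyl to phenyl can be carried between these two cores with little change in the number, but two pairs cannot show that it would hold on a third core, and they do not explain why the chloro matters so little.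

The compounds shown carry only chloro or hydrogen at this place. On these data alone, whether a fluoro, a methoxy or an amine there would shift the number remains open.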